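The source may report more compounds than this note shows. Statements on the series, on what has been measured and on what is new or still open speak of the compounds shown alone.

compound 1 `CCCCn1cc(C(=O)NCc2ccccc2)c(=O)c2cc(F)c(N(C)C)cc21`: 2.4
compound 2 `CCCCn1cc(C(=O)NCc2ccc([N+](=O)[O-])cc2)c(=O)c2cc(F)c(N3CCC(C(N)=O)CC3)cc21`: 2.4

In a physicochemical assay for lipophilicity, read by HPLC (on this read-out lower numbers stand for lower lipophilicity and higher numbers for higher lipophilicity), compound 2 stands level with compound 1, the two values lying within the usual scatter of each other. Within the data shown here, these two compounds differ in more than one place, so no measured step speaks directly to the next change. Compound 3 `CCCCn1cc(C(=O)NCc2ccc(OC)cc2)c(=O)c2cc(F)c(N3CCC(C(N)=O)CC3)cc21` keeps compound 2 except for one group, with methoxy in place of nitro on an aromatic carbon. Starting from compound 2 at 2.4, the expected a number 0.10 log units higher from compound 2 to compound 3 (within the scatter) is a slight rise that stays within the scatter. The estimate for compound 3 is 2.5, expected to fall between 2.2 and 2.9.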

Compound 3, partition coefficient: 2.4
Compound 3: the middle estimate sits 0.10 log units above what was measured; the measured number falls inside the stated range.
By their numbers in this assay, from the lowest: compounds 1, 2 and 3 (each within the scatter of the next).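

In this assay, among these compounds, the exchange of nitro for methoxy on the aromatic carbon gives no change at the digits printed from compound 2 to compound 3 (within the scatter), the first comparison here between compounds that differ in only one place. At this position, then, a group of three heavy atoms and one of two read alike, although the hydrogen-bond acceptor counts also differ. Nothing measured here explains that match.

From the compounds shown here alone, whether an amine, a carboxylic acid or a longer chain at this position would read alike remains open. So does whether the same exchange would give this result in compounds that differ elsewhere.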